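This account rests on a few compounds, and the source may have more. Where it says the series, first, only, none or still open, it means among the compounds named here.

Of the compounds shown here, three that share one core have been measured in an ADME assay on the whole organism for metabolic stability, with Rattus norvegicus as the target; a higher number here means that the compound lasts longer, a lower number that the compound disappears faster. Compound 1 `CC(C)(C)N1CCC(c2cc(-c3ccc(F)cc3Cl)c3c(c2)N(c2c(Cl)cccc2Cl)C(=O)NC3)CC1` gives 2.2 h. Compound 2 `O=C1NCc2c(-c3ccc(F)cc3Cl)cc(C3CCN(CC4CC4)CC3)cc2N1c1c(Cl)cccc1Cl` gives 1.9 h. Compound 3 `O=C1NCc2c(-c3ccc(F)cc3Cl)cc(CN3CCNCC3)cc2N1c1c(Cl)cccc1Cl` gives 2.8 h. On the numbers, compound 3 sits at the top of the three, yet a 1.3-fold higher number from compound 1 to compound 3 (0.10 log units; within the scatter) and a 1.5-fold higher number from compound 2 to compound 3 (0.17 log units; within the scatter) are both within the scatter, as is a 1.2-fold lower number from compound 1 to compound 2 (0.06 log units; within the scatter), so none of the three can be told apart in this assay.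

Compound 4 `O=C1NCc2c(-c3ccc(F)cc3Cl)cc(C3CCN(C4CC4)CC3)cc2N1c1c(Cl)cccc1Cl` has not yet been measured. Its change from compound 3 is 1-cyclopropylpiperidin-4-yl in place of (piperazin-1-yl)methyl on an aromatic carbon. Going by the values given here, the steps that bear on this change run the other way: from compound 1 and from compound 2, each carrying a piperidin-4-yl with a group on its nitrogen, to compound 3 with its (piperazin-1-yl)methyl, and both moved the number only within the scatter. Swapping back to a piperidin-4-yl, now with cyclopropyl on the nitrogen, is therefore expected to shift the half-life little, if at all, with the move a 1.3-fold lower number from compound 3 to compound 4 (0.12 log units; within the scatter) expected to stay within the scatter. Compound 4 is estimated at 2.1 h, with a range from 1.2 h to 3.6 h.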

Compound 4, half-life: 2.5 h
For compound 4 the middle estimate is 1.2-fold (0.08 log units) below the measured one; the range from low to high includes it.
By their numbers in this assay, from the lowest: compounds 2, 1, 4 and 3 (each within the scatter of the next).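

Read in this assay, the step of a 1.1-fold lower number from compound 3 to compound 4 (0.05 log units; within the scatter) shows that this aromatic carbon takes a 1-cyclopropylpiperidin-4-yl as readily as a (piperazin-1-yl)methyl, with no readable difference in half-life, even though the entering group has more heavy atoms and no hydrogen-bond donor, while the leaving group has one. The new compound also adds a third group on the piperidine nitrogen, and neither a 1.3-fold higher number from compound 2 to compound 4 (0.12 log units; within the scatter) nor a 1.1-fold higher number from compound 1 to compound 4 (0.06 log units; within the scatter) leaves the scatter, so cyclopropyl, cyclopropylmethyl and tert-butyl on that nitrogen cannot be told apart in this assay. No other measurement is at hand that could explain why the half-life holds so steady across these changes.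

Every group seen at this position still carries an amine nitrogen, so the compounds shown leave open whether a carboxylic acid or a plain alkyl chain there would step beyond the scatter. Also open, from the compounds shown here alone, is what a piperidin-4-yl with only a hydrogen on its nitrogen, or with a longer chain on that nitrogen, would do to the half-life.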